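Meta-substituted dihydropyridines in guinea-pig muscle

The compounds below may be only part of what the source reports. "The series", "measured", "known", "first", "only" and "open" are said of these compounds alone.

Compound 1, `COC(=O)C1=C(C)N=C(C)/C(=C(\O)OC)C1c1cccc(N)c1`: 2000 nM
Compound 2, `COC(=O)C1=C(C)N=C(C)/C(=C(\O)OC)C1c1cccc(I)c1`: 41.7 nM
Compound 3, `COC(=O)C1=C(C)N=C(C)/C(=C(\O)OC)C1c1cccc(C)c1`: 110 nM

Three compounds share one core and differ only in the group on the phenyl ring. In a functional assay (muscle tissue) with Cavia porcellus as the target (a lower number here means that less compound is needed, a higher number that more compound is needed for the effect), compound 1 gives 2000 nM, compound 2 gives 41.7 nM and compound 3 gives 110 nM. Compound 3 thus stands second of the three: it lies a 2.6-fold higher number from compound 2 to compound 3 (0.42 log units; beyond the scatter) and an 18-fold lower number from compound 1 to compound 3 (1.26 log units; beyond the scatter).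

Compound 4, `COC(=O)C1=C(C)N=C(C)/C(=C(\O)OC)C1c1cccc(C#N)c1`, has not yet been measured. It differs from compound 3 in one place: cyano in place of methyl on an aromatic carbon

Within the data shown here, no measured step involves cyano, so the steps from compound 1 and compound 2 to compound 3 bear on it only indirectly. They show that changing the group at this position moves this assay by large or modest amounts in both directions, with amino far weaker than iodo or methyl. Compound 4 is therefore expected to differ from compound 3 by a modest step, a 1.8-fold lower number from compound 3 to compound 4 (0.26 log units; within the scatter), with a lower number considered somewhat more likely than a higher one. The estimate for compound 4 is 60 nM, within a range of 15 nM to 250 nM.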

Compound 4, half-maximal effective concentration: 34.7 nM
Beside the measured number, compound 4's estimate is 1.7-fold (0.24 log units) above it, within the range that was stated.
By their numbers in this assay, from the lowest: compounds 4 and 2 (each within the scatter of the next); then compound 3; then compound 1.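

In this assay, among these compounds, putting cyano in place of methyl on this aromatic carbon gives a 3.2-fold lower number from compound 3 to compound 4 (0.50 log units; beyond the scatter) and so shows that iodo is not the only group here to give a lower number than methyl. Set against iodo, the same group gives a 1.2-fold lower number from compound 2 to compound 4 (0.08 log units; within the scatter) and cannot be told apart from it, even though the two share no atom. Set against amino, it gives a 58-fold lower number from compound 1 to compound 4 (1.76 log units; beyond the scatter) and thus confirms the wide gap between amino and the other groups at this position.

On these data alone, whether a carboxylic acid, a methoxy group or a longer chain on this carbon would also keep the number as low as cyano and iodo remains open. Nothing available here explains why these groups differ in this way.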